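Swapping Propyl for Phenyl on a Shared Core

The compounds below may be only part of what the source reports. "The series", "measured", "known", "first", "only" and "open" are said of these compounds alone.

In a functional assay on SW620/5-FU cells (Homo sapiens) for cytotoxicity, read by MTT assay, with a stated time of 48 h, in the presence of a further agent that is not named here (a higher number here means that more compound is needed for the effect, a lower number that less compound is needed), compound 1 `CCCc1cc(NNC(=O)Nc2cc(Cl)nc(Cl)c2)nc2c1c(C)nn2C` gives 40800 nM. Going by the values given here, the only other measured compound, compound 2 `COc1ccc(-c2cc(NNC(=O)Nc3cc(Br)nc(Br)c3)nc3c2cnn3C)cc1`, gives 54100 nM. These two numbers lie within the usual scatter, so neither compound can be ranked above the other. Compound 3 `Cc1nn(C)c2nc(NNC(=O)Nc3cc(Cl)nc(Cl)c3)cc(-c3ccccc3)c12` has not been measured yet. It keeps the core of compound 1 but has phenyl in place of propyl on an aromatic carbon, opposite the ring nitrogen: phenyl in place of propyl on an aromatic carbon. Among the compounds with values here, no measured pair isolates this change, so any forecast is loose. Within the data shown here, the one hint is compound 2, which also carries an aromatic ring and gives 54100 nM, although it differs in other places too. No change beyond the scatter is therefore expected in this assay. The estimated step of a 1.1-fold higher number from compound 1 to compound 3 (0.04 log units; within the scatter) reflects this. Compound 3 is expected at 45000 nM, with an estimated range of 18000 nM to 100000 nM.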

Compound 3, half-maximal effective concentration: 22900 nM
For compound 3 the middle estimate is 2.0-fold (0.29 log units) above the measured one; low and high end bracket the measured number.
By their numbers in this assay, from the lowest: compounds 3, 1 and 2 (each within the scatter of the next, the first and the last beyond it).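

Going by these compounds alone, this is the first pair to isolate a single change at this position, on an aromatic carbon opposite the ring nitrogen. In this assay, phenyl in place of propyl gives a 1.8-fold lower number from compound 1 to compound 3 (0.25 log units; within the scatter), so on this core the position takes a six-membered aromatic ring as well as a propyl chain, with no change beyond the scatter. Nothing shown here explains why the two groups read alike.

Going by these compounds, it remains open how a primary amine, a carboxylic acid or a chain longer than propyl would read at this carbon in this assay. On these data alone, it is also open whether phenyl and propyl would still read alike with bromine in place of chlorine elsewhere on the molecule.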